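Replacing Isobutyl with Phenyl on the Quinoline-Like Core

This account rests on a few compounds, and the source may have more. Where it says the series, first, only, none or still open, it means among the compounds named here.

Among three compounds measured in an ADME assay on HepG2 cells (Homo sapiens) for cytotoxicity, read by luminescence, CellTiter-Glo and ATP content, with a stated time of 72 h (a higher number here means that more compound is needed for the effect, a lower number that less compound is needed), compound 2 `CC(C)Cc1ccc2c(NCCCNCc3ccco3)ccnc2c1` stands highest with 16000 nM. Compound 3 `CCC(CC)c1ccc2c(NCCCNCc3cc(F)ccc3OC)ccnc2c1` gives 7860 nM, and compound 1 `COc1ccc(-c2ccc3c(NCCCNCc4cccc(OC)c4O)ccnc3c2)cc1`, which also carries an aromatic group at the same place, gives 1600 nM. Compound 4 `c1ccc(-c2ccc3c(NCCCNCc4ccco4)ccnc3c2)cc1` has not yet been measured. It differs from compound 2 by phenyl in place of isobutyl on an aromatic carbon. Within the data shown here, no step between two measured compounds isolates this change, so only the neighbours guide expectation. Because compound 1 shows 1600 nM, a lower number than compound 2, the aromatic replacement is expected to move compound 4 downward in this assay by a 2.7-fold lower number from compound 2 to compound 4 (0.43 log units; beyond the scatter), beyond the scatter. Compound 4 is therefore estimated at 6000 nM, with a range from 2000 nM to 16000 nM.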

Compound 4, half-maximal effective concentration: 5920 nM
Compound 4: middle estimate off by 1.0-fold (0.01 log units), on the high side; measured number inside the range.
By their numbers in this assay, from the lowest: compound 1; then compounds 4 and 3 (each within the scatter of the next); then compound 2.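

Among these compounds, this step is the first to isolate the group at this place. With the rest of compound 2 unchanged, phenyl in place of isobutyl on an aromatic carbon gives in this assay a 2.7-fold lower number from compound 2 to compound 4 (0.43 log units; beyond the scatter) and so shows that this position alone can shift the number, though only modestly. Nothing available explains the shift.

As far as these compounds go, whether the step holds with the other side chains, such as that of compound 1, remains open. So does how an amine, a carboxylic acid or a plain methyl at this place would read.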